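Benzyl in place of ethyl on the ring nitrogen

This account rests on a few compounds, and the source may have more. Where it says the series, first, only, none or still open, it means among the compounds named here.

Compound 3 `CCN1CCC(C(=O)Nc2cc(Cl)c(N)cc2OC)CC1` is known in a functional assay on the whole organism for antagonist activity, with Mus musculus as the target (a lower number here means that less compound is needed, a higher number that more compound is needed for the effect), only as a limit of the assay, not a number: compound 3 gives > 10 mg/kg. Compound 1 `CCCCN1CCC(C(=O)Nc2cc(Cl)c(N)cc2OC)CC1` likewise stands at a limit, > 10 mg/kg. Compound 2 `CCOc1ccc(CN2CCC(C(=O)Nc3cc(Cl)c(N)cc3OC)CC2)cc1` gives a number, 6.3 mg/kg. Across the three, (the limit of > 10 mg/kg in this assay, at which 2 of the 3 values shown sit).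

Compound 4 `COc1cc(N)c(Cl)cc1NC(=O)C1CCN(Cc2ccccc2)CC1` differs from compound 3 by phenyl in place of methyl on a saturated chain carbon bound to an amine nitrogen in a ring. The measured steps that bear on this are an at least 1.5-fold lower number from compound 1 to compound 2 (0.20 log units; that floor lies within the scatter) and an at least 1.5-fold higher number from compound 2 to compound 3 (0.20 log units; that floor lies within the scatter); in both, the aromatic group on that carbon goes with the lower number, though each step is read only against a limit. A step of similar size downward is therefore expected, an at least 1.2-fold lower number from compound 3 to compound 4 (0.09 log units; that floor lies within the scatter). Compound 4 is expected to give 8 mg/kg, within 3 mg/kg to 20 mg/kg.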

Compound 4, dose for half-maximal effect: 0.5 mg/kg
Compound 4: middle estimate off by 16-fold (1.20 log units), on the high side, outside the stated range (below it).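

For the compounds shown here, on the ring nitrogen, benzyl counts for far more in this assay than the earlier compounds showed (an at least 20-fold lower number from compound 3 to compound 4 (1.30 log units; beyond the scatter)) (an at least 20-fold lower number from compound 1 to compound 4 (1.30 log units; beyond the scatter)). Both steps are floors, read against a limit: the limit of > 10 mg/kg in this assay, at which 2 of the 4 values shown sit. Going by these compounds alone, an aromatic ring on that carbon is not sufficient alone, as hydrogen in place of ethoxy gives the one step with numbers at both ends (a 13-fold lower number from compound 2 to compound 4 (1.10 log units; beyond the scatter)).

On these data alone, whether a fluorine or a methoxy in place of that hydrogen, or a longer chain to the phenyl, keeps this level stays open. The compounds shown give no cause for the size of these steps.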